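A few compounds are considered here, and "the series" means these few. Any claim that something is new, unique, unknown or untested is made for them only; others in the source may bear on it.

Of the compounds shown here, two have been measured so far in a functional assay on MCF7 cells (Homo sapiens) for inhibition, read by MTT assay, with a stated time of 48 h, tested at 10 uM; a higher number here means more inhibition of growth at the concentration tested, a lower number less inhibition of growth. Compound 1 (`COc1ccc(COc2cc(O)c3c(=O)cc(C)oc3c2[C@H]2CCN(C)C[C@H]2O)cc1`) gives 16%, and compound 2 (`Cc1cc(=O)c2c(O)c(CN3CCCC3CO)c(O)c([C@H]3CCN(C)C[C@H]3O)c2o1`) gives 22%. These two values lie within the usual scatter of each other, so compound 2 stands level with compound 1 on the numbers available.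

Compound 3 (`Cc1cc(=O)c2c(O)c(CN3CC(O)CC3C(=O)O)c(O)c([C@H]3CCN(C)C[C@H]3O)c2o1`) has not yet been measured. It differs from compound 2 in one place, on a saturated chain carbon bound to an aromatic carbon, where 2-carboxy-4-hydroxypyrrolidin-1-yl appears in place of 2-(hydroxymethyl)pyrrolidin-1-yl (2-carboxy-4-hydroxypyrrolidin-1-yl in place of 2-(hydroxymethyl)pyrrolidin-1-yl on a saturated chain carbon bound to an aromatic carbon). Within the data shown here, no measured pair shows the effect of such a swap, so only a small downward move, within the scatter, is expected. The expected step is a number 6 percentage points lower from compound 2 to compound 3 (within the scatter). In this assay, the estimate for compound 3 is 16%, expected to fall between 4% and 30%.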

Compound 3, percent growth inhibition at one concentration: 25%
The estimate for compound 3 lay 9 percentage points below the measured number; the range from low to high includes it.
By their numbers in this assay, from the lowest: compounds 1, 2 and 3 (each within the scatter of the next).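

On a saturated chain carbon bound to an aromatic carbon, putting 2-carboxy-4-hydroxypyrrolidin-1-yl in place of 2-(hydroxymethyl)pyrrolidin-1-yl gives a number 3 percentage points higher from compound 2 to compound 3 (within the scatter). So this assay does not separate these two groups, even though the entering group has 9 heavy atoms against 7 and brings a carboxy group and a ring hydroxy group together. Nothing shown here gives a reason for this result.

As far as these compounds go, the swap alters two features at once, so the separate contributions of the carboxy group and the ring hydroxy group remain unknown; a pyrrolidine ring carrying only a carboxy group would address the first. The compounds shown also leave open whether a pyrrolidine ring is needed here at all, a question that a morpholin-4-yl ring or an open-chain dimethylamino group would test.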